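Amide variation in a dienamide series: compound 4

This account rests on a few compounds, and the source may have more. Where it says the series, first, only, none or still open, it means among the compounds named here.

Measured so far:
compound 1, `COc1ccc(C[C@@H](O)/C=C/C=C/C(=O)NCc2ccccc2)cc1OC`, 33600 nM
compound 2, `COc1ccc(CNC(=O)/C=C/C=C/[C@H](O)Cc2ccc(OC)c(OC)c2)cc1`, 26600 nM
compound 3, `COc1ccc(C[C@@H](O)/C=C/C=C/C(=O)N2CCN(c3ccccc3)CC2)cc1OC`, 12000 nM

In a functional assay on MCF7 cells (Homo sapiens) for antiproliferative activity, read by sulforhodamine B assay, with a stated time of 48 h (a higher number here means a weaker inhibitor, a lower number a stronger inhibitor), compound 1 stands highest of the three numbers. Compound 2 lies nearest: the step of a 1.3-fold lower number from compound 1 to compound 2 (0.10 log units; within the scatter) is within the scatter. Among the measured compounds shown here, compound 3 lies furthest, its value being lower than that of compound 1 beyond the scatter; no single-point step between these two is set out, so only the two values themselves can be compared.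

Compound 4, `COc1ccc(C[C@@H](O)/C=C/C=C/C(=O)N2CCCC2)cc1OC`, differs from compound 1 by pyrrolidin-1-yl in place of benzylamino on a carbonyl carbon. For the measured compounds named here, the one measured step, from compound 1 to compound 2, concerns the aromatic ring rather than the amide and is within the scatter, so it does not bear directly on this change. The values of compounds 1 and 3 show a lower number where the amide nitrogen sits in a ring, but that rests on one pair only. A modest step downward, or none beyond the scatter, is therefore expected for compound 4: a 1.3-fold lower number from compound 1 to compound 4 (0.13 log units; within the scatter). Compound 4 is estimated at 25000 nM, with a range from 10000 nM to 60000 nM.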

Compound 4, half-maximal inhibitory concentration: 26200 nM
Compound 4: the middle estimate sits 1.0-fold (0.02 log units) below what was measured, and the stated range covers the measured number.
By their numbers in this assay, from the lowest: compound 3; then compounds 4, 2 and 1 (each within the scatter of the next).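

In this assay, pyrrolidin-1-yl in place of benzylamino on the carbonyl carbon gives a 1.3-fold lower number from compound 1 to compound 4 (0.11 log units; within the scatter). Among the compounds shown here, this is the first single-place step read at the amide, and it shows that this position tolerates loss of the benzylamino aromatic ring and the amide hydrogen with the number staying within the scatter. The compounds shown leave open whether morpholin-4-yl or diethylamino on the same carbonyl carbon would also stay within the scatter, and whether a carboxylic acid in place of the amide would do so. Nothing at hand bears on the cause of this result.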